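The compounds below may be only part of what the source reports. "The series", "measured", "known", "first", "only" and "open" are said of these compounds alone.

Compound 1 `Cc1noc(C)c1-c1cnc(N)c(Oc2ccc(C(=O)NC3CCCCC3)cc2)n1`: 21600 nM
Compound 2 `Cc1noc(C)c1-c1cnc(N)c(Oc2ccc(C(=O)Nc3ccccc3Cl)cc2)n1`: > 100000 nM

Both compounds were tested in a functional assay on LoVo cells (Homo sapiens) for inhibition, read by MTT assay, with a stated time of 72 h; a lower number here means a stronger inhibitor, a higher number a weaker inhibitor. Compound 1 gives a high number there, so it is a weak inhibitor. Compound 2 gives only a limit in this assay, namely (the limit of > 100000 nM in this assay, at which 1 of the 2 values shown sits), so its true number is not known. Among the measured compounds shown here, the one measured step, an at least 4.6-fold higher number from compound 1 to compound 2 (0.66 log units; beyond the scatter), went in the weakening direction when the cyclohexyl group was exchanged for a 2-chlorophenyl group.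

Compound 3 `Cc1noc(C)c1-c1cnc(N)c(Oc2ccc(C(=O)Nc3cccc(Cl)c3)cc2)n1` is the next step: 3-chlorophenyl in place of 2-chlorophenyl on an amide-type nitrogen. For the measured compounds named here, this is a rearrangement of the same atoms rather than an exchange of groups, and no measured step speaks to it directly. The expectation for compound 3 in this assay is therefore an unchanged picture, a step of an at least 1.1-fold lower number from compound 2 to compound 3 (0.04 log units; that floor lies within the scatter), with compound 3 staying a weak inhibitor. The estimated value for compound 3 in this assay is 90000 nM, with a range from 25000 nM to 300000 nM.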

Compound 3, half-maximal inhibitory concentration: 1640 nM
Estimate against measurement, compound 3: 55-fold (1.74 log units) above, outside the stated range (below it).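

In this assay, where the chlorine sits on the phenyl group on this amide nitrogen matters greatly, even though the atoms stay the same: moving it gives an at least 60-fold lower number from compound 2 to compound 3 (1.78 log units; beyond the scatter). As far as these compounds go, compound 2 gives only a limit, so that step is a floor and its true size is unknown: the limit of > 100000 nM in this assay, at which 1 of the 3 values shown sits. Nor does an aromatic group on this nitrogen weaken the compound in every case: exchanging cyclohexyl for 3-chlorophenyl gives a 13-fold lower number from compound 1 to compound 3 (1.12 log units; beyond the scatter), the opposite direction to the exchange for 2-chlorophenyl.

The compounds shown leave open whether the chlorine itself adds to the strength, which a plain phenyl group would test, and how a 4-chlorophenyl group compares. They also cannot tell whether another group, such as 3-methoxyphenyl or 3-fluorophenyl, would serve as well as 3-chlorophenyl.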